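The source may report more compounds than this note shows. Statements on the series, on what has been measured and on what is new or still open speak of the compounds shown alone.

Compound 1 `O=C(Nc1cccc(-c2oc3cc(-c4ccc(F)cc4)ccc3c(=O)c2O)c1)c1ccc(F)cc1F`: in a functional assay on GTL 16 cells for antiproliferative activity against GTL 16 cell line (Homo sapiens), read by CCK-8 assay, with a stated time of 72 h (a lower number here means a stronger inhibitor, a higher number a weaker inhibitor), compound 1 gives 9640 nM
Compound 2 `COc1ccccc1C(=O)Nc1cccc(-c2oc3cc(-c4ccc(F)cc4)ccc3c(=O)c2O)c1`: compound 2 gives 6370 nM
Compound 3 `O=C(Nc1cccc(-c2oc3cc(-c4ccc(F)cc4)ccc3c(=O)c2O)c1)c1ccc(C(F)(F)F)cc1`: compound 3 gives 33000 nM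

Compound 3 gives the highest number of the three in this assay, with a 3.4-fold higher number from compound 1 to compound 3 (0.53 log units; beyond the scatter) and a 5.2-fold higher number from compound 2 to compound 3 (0.71 log units; beyond the scatter). Compound 4 `CCc1ccc(C(=O)Nc2cccc(-c3oc4cc(-c5ccc(F)cc5)ccc4c(=O)c3O)c2)cc1` differs from compound 3 by ethyl in place of trifluoromethyl on an aromatic carbon. Going by the values given here, no measured step swaps the trifluoromethyl for an alkyl group; the only steps that bear on the change show that compound 3, the trifluoromethyl member, stands beyond the scatter above compounds 1 and 2. Each move away from the trifluoromethyl so far gave a lower number, so a modest decrease in this assay is expected for compound 4, a 2.5-fold lower number from compound 3 to compound 4 (0.40 log units; beyond the scatter). Compound 4 is therefore estimated at 13000 nM, within 5000 nM to 35000 nM.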

Compound 4, half-maximal inhibitory concentration: 24600 nM
Compound 4: middle estimate off by 1.9-fold (0.28 log units), on the low side; the measured number falls inside the stated range.
By their numbers in this assay, from the lowest: compounds 2 and 1 (each within the scatter of the next); then compounds 4 and 3 (each within the scatter of the next).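

In this assay the step of a 1.3-fold lower number from compound 3 to compound 4 (0.13 log units; within the scatter) shows that this aromatic carbon tolerates ethyl in place of trifluoromethyl with no readable change. The steps of a 3.9-fold higher number from compound 2 to compound 4 (0.59 log units; beyond the scatter) and a 2.6-fold higher number from compound 1 to compound 4 (0.41 log units; beyond the scatter) show that the 4-ethylphenyl group, like 4-(trifluoromethyl)phenyl, stands beyond the scatter from the 2-methoxyphenyl and 2,4-difluorophenyl groups. Nothing available explains these differences.

From the compounds shown here alone, it remains open whether an amine, a carboxylic acid or a longer chain on this carbon would give a lower number. A lone methoxy or fluorine at this same place is also untested among these compounds.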